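Fluoro on the benzamide ring of the pyrazolyl-pyridine series

The source may hold more compounds than are shown below. What is called first, only, known or untested is meant among the compounds shown, and "the series" means these compounds.

Compound 1 `COc1cccc(-c2nn(-c3ccccc3)cc2-c2ccnc(NCCCNC(=O)Nc3ccc(Cl)c(Cl)c3)c2)c1` carries a urea to a dichlorophenyl and a methoxyphenyl on the pyrazole; in a functional assay on MDA-MB-468 cells (Homo sapiens) for cytotoxicity (a higher number here means that more compound is tolerated, a lower number that less compound is tolerated), compound 1 gives 9820 nM. Compound 2 `O=C(NCCCNc1cc(-c2cn(-c3ccccc3)nc2-c2cccc(O)c2)ccn1)c1ccccc1` replaces the urea by a benzamide on the same propyl linker and the methoxy by a phenol; in this assay compound 2 gives "not determined" (no result reported), so no single number places compound 2 on the scale, and only compound 1 gives a point of reference for the series. Compound 3 `O=C(NCCCNc1cc(-c2cn(-c3ccccc3)nc2-c2cccc(O)c2)ccn1)c1ccc(F)cc1` differs from compound 2 by fluoro in place of hydrogen on an aromatic carbon. Among the measured compounds shown here, no step between measured compounds describes this change, so no direction beyond the scatter of this assay is expected for it; the estimate rests on the value of compound 1 alone. Compound 3 is expected to reach 10000 nM in this assay, within 2500 nM to 40000 nM.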

Compound 3, concentration lethal to 50% of the cells: 6920 nM
Compound 3: middle estimate off by 1.4-fold (0.16 log units), on the high side, and the stated range covers the measured number.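

No step can be read between compound 2 and compound 3, since compound 2 has no single number in this assay to set against compound 3 at 6920 nM here. The compounds shown leave open whether 4-fluorophenyl in place of phenyl shifts this read-out. No supporting data bear on a cause.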